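Dipropylamino for butylamino on the thiocarbonyl carbon

The source may report more compounds than this note shows. Statements on the series, on what has been measured and on what is new or still open speak of the compounds shown alone.

Of the compounds shown here, three sharing one core have been measured in a functional assay on DU-145 cells (Homo sapiens) for cytotoxicity, read by MTT assay, with a stated time of 72 h; on this read-out lower numbers stand for stronger inhibition and higher numbers for weaker inhibition. Compound 1 `CC(C)NC(=S)N/N=C1\CC(c2ccc(O)cc2)Oc2cc(O)ccc21` gives 60400 nM. Compound 2 `Oc1ccc(C2C/C(=N\NC(=S)N3CCOCC3)c3ccc(O)cc3O2)cc1` gives 84500 nM. Compound 3 `CCCCNC(=S)N/N=C1\CC(c2ccc(O)cc2)Oc2cc(O)ccc21` gives 57700 nM, within the scatter of both others.

The next structure is compound 4 `CCCN(CCC)C(=S)N/N=C1\CC(c2ccc(O)cc2)Oc2cc(O)ccc21`. The change is dipropylamino in place of butylamino on a thiocarbonyl carbon.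

Going by the values given here, three measured steps bear on it. Changing only the chain gives a 1.0-fold lower number from compound 1 to compound 3 (0.02 log units; within the scatter). Exchanging morpholin-4-yl for butylamino gives a 1.5-fold lower number from compound 2 to compound 3 (0.17 log units; within the scatter), and exchanging isopropylamino for morpholin-4-yl gives a 1.4-fold higher number from compound 1 to compound 2 (0.15 log units; within the scatter). Among the compounds with values here, all three lie within the scatter, although only three compounds support this reading and none carries dipropylamino. No step beyond the scatter is therefore expected in this assay. The estimated step is a 1.1-fold higher number from compound 3 to compound 4 (0.05 log units; within the scatter). For compound 4 the expected value is 65000 nM, with an estimated range of 30000 nM to 130000 nM.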

Compound 4, half-maximal inhibitory concentration: 62100 nM
Compound 4: the middle estimate sits 1.0-fold (0.02 log units) above what was measured; measured number inside the range.
By their numbers in this assay, from the lowest: compounds 3, 1, 4 and 2 (each within the scatter of the next).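

At the thiocarbonyl carbon, dipropylamino in place of butylamino removes the hydrogen-bond donor of butylamino and adds carbon, yet this assay shows a 1.1-fold higher number from compound 3 to compound 4 (0.03 log units; within the scatter) as the only consequence. The same group set against the other two substituents gives a 1.4-fold lower number from compound 2 to compound 4 (0.13 log units; within the scatter) and a 1.0-fold higher number from compound 1 to compound 4 (0.01 log units; within the scatter), so the read-out does not separate this group from morpholin-4-yl or isopropylamino, and the four compounds now cover both donor-bearing and donor-free groups at this carbon without a step beyond the scatter. Nothing available on these compounds accounts for this flat response.

As far as these compounds go, whether any group at this carbon can move the number beyond the scatter remains open, for instance a carboxylic acid or a primary amine carried on a longer chain. Also open, from the compounds shown here alone, is whether the hydroxyl groups of the shared core matter more than this position does.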